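The source may report more compounds than this note shows. Statements on the series, on what has been measured and on what is new or still open speak of the compounds shown alone.

Compound 1 `COc1cc2cc(Oc3ccc(NC(=O)Nc4ccc(C(F)(F)F)cc4)cc3)c(C)nc2cc1OC` gives 113% in a functional assay on BT-549 cells (Homo sapiens) for inhibition, read by sulforhodamine B assay, with a stated time of 48 h, tested at 10 uM; on this read-out lower numbers stand for a stronger effect and higher numbers for a weaker effect at the one concentration tested; compound 2 `COc1cc2cc(Oc3ccc(NC(=O)Nc4cccc(C(F)(F)F)c4)cc3)c(C)nc2cc1OC` gives -8.13% in this assay; compound 3 `COc1cc2cc(Oc3ccc(NC(=O)Nc4ccc(Cl)c(C(F)(F)F)c4)cc3)c(C)nc2cc1OC` gives -38.7% in this assay.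

Compound 3 stands lowest of the three: the nearest is compound 2, with a number 30.6 percentage points lower from compound 2 to compound 3 (beyond the scatter), and the furthest is compound 1, with a number 151.7 percentage points lower from compound 1 to compound 3 (beyond the scatter). Compound 4 `COc1cc2cc(Oc3ccc(NC(=O)Nc4ccc(Cl)c(Cl)c4)cc3)c(C)nc2cc1OC` differs from compound 3 by chloro in place of trifluoromethyl on an aromatic carbon. For the measured compounds named here, no measured step swaps chloro for trifluoromethyl; a number 30.6 percentage points lower from compound 2 to compound 3 (beyond the scatter) concerns only the chloro that compound 4 keeps, and a number 121.1 percentage points lower from compound 1 to compound 2 (beyond the scatter) concerns position, not group. The expected step is therefore a number 13.7 percentage points higher from compound 3 to compound 4 (beyond the scatter), within the scatter. Compound 4 is estimated at -25%, between -60% and 15%.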

Compound 4, a percentage reported as activity, at one concentration (the size of the read-out at that concentration, not a potency): 28.1%
Beside the measured number, compound 4's estimate is 53.1 percentage points below it; the whole stated range lies below it.
By their numbers in this assay, from the lowest: compound 3; then compound 2; then compound 4; then compound 1.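

On an aromatic carbon ortho to a chloro group, in this assay chloro does not stand in for trifluoromethyl, and the swap weakens the effect (a number 66.8 percentage points higher from compound 3 to compound 4 (beyond the scatter)). The 3,4-dichlorophenyl group ranks on neither side of the earlier pair alone: it reads weaker than 3-(trifluoromethyl)phenyl (a number 36.2 percentage points higher from compound 2 to compound 4 (beyond the scatter)) yet stronger than 4-(trifluoromethyl)phenyl (a number 84.9 percentage points lower from compound 1 to compound 4 (beyond the scatter)). No evidence is available that bears on these steps. The compounds shown leave open how a bromo, a nitrile or a methoxy group would read on this carbon.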